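Cyclopentyl Ester in Place of Isopropyl Amide at Compound 4

The source may report more compounds than this note shows. Statements on the series, on what has been measured and on what is new or still open speak of the compounds shown alone.

Compound 1, `CCCC(=O)C1=C(C)NC(=O)NC1c1ccsc1`: 1%
Compound 2, `CC1=C(C(=O)NC(C)C)C(c2ccco2)NC(=O)N1`: 4%
Compound 3, `CC1=C(C(=O)NC(C)C)C(c2ccsc2)NC(=O)N1`: 1%

In an assay on membranes from HeLa cells for displacement of a labelled ligand from adenosine receptor A3 (Homo sapiens), read by scintillation counting, with a stated time of 180 min, tested at 1 uM (a lower number here means less inhibition, a higher number more inhibition at the concentration tested (going by the name of the read-out)), compound 3 gives 1%, level with compound 1 at the digits shown; together they are the lowest of the three numbers, and compound 2 sits higher only within the scatter. The two measured steps leading to compound 3 are small: no change at the digits printed from compound 1 to compound 3 (within the scatter) and a number 3 percentage points lower from compound 2 to compound 3 (within the scatter). Compound 4, `CC1=C(C(=O)OC2CCCC2)C(c2ccsc2)NC(=O)N1`, differs from compound 3 at the carbonyl carbon: cyclopentyloxy in place of isopropylamino on a carbonyl carbon. For the measured compounds named here, the only step at this carbonyl carbon, no change at the digits printed from compound 1 to compound 3 (within the scatter), moved nothing, so no step beyond the scatter is expected, a number 2 percentage points higher from compound 3 to compound 4 (within the scatter). Compound 4 is therefore estimated at 3%, with a range from 0% to 15%.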

Compound 4, a percentage reported as inhibition, at one concentration (the size of the read-out at that concentration, not a potency): 5%
Compound 4: middle estimate off by 2 percentage points, on the low side, within the range that was stated.
By their numbers in this assay, from the lowest: compounds 1, 3, 2 and 4 (each within the scatter of the next).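

In this assay cyclopentyloxy on the carbonyl carbon, with its ring and no hydrogen-bond donor, reads much like isopropylamino (a number 4 percentage points higher from compound 3 to compound 4 (within the scatter)) and propyl (a number 4 percentage points higher from compound 1 to compound 4 (within the scatter)). Losing the hydrogen-bond donor of isopropylamino and gaining a ring at this place therefore moves the number only within the scatter. No measurement at hand bears on why.

Going by these compounds, what a carboxylic acid or a benzyl ester on this carbonyl carbon would give stays open. So does whether cyclopentyloxy reads the same with furan-2-yl in place of thiophen-3-yl.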